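A few compounds are considered here, and "the series" means these few. Any claim that something is new, unique, unknown or untested is made for them only; others in the source may bear on it.

Working notes on the series. Compound 1 `C=CCOc1ccc(C(=O)Nc2ccccn2)cc1` gives 19300 nM in an in vitro assay on HEK-tsA201 cells for antagonist activity at Neuronal acetylcholine receptor; alpha4/beta2 (Homo sapiens), read by fluorescence and calcium flux; on this read-out lower numbers stand for stronger inhibition and higher numbers for weaker inhibition. Compound 2 `CCCOc1ccc(C(=O)Nc2cnccn2)cc1` gives 23200 nM in this assay. Compound 3 `CCCCNc1cccc(NC(=O)c2ccc(OCCC)cc2)n1` gives 54100 nM in this assay, the highest of the three numbers; its gap to compound 2 and its wider gap to compound 1 both fall beyond the scatter, so compound 3 is the weakest of the three. Going by the values given here, no pair of measured compounds differs in a single place, so none of these gaps can be read as the effect of one change.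

Compound 4 `CCCOc1ccc(C(=O)Nc2cccc(Nc3ccc(Cl)cc3)n2)cc1` follows from compound 3 by 4-chlorophenyl in place of butyl on a nitrogen on an aromatic ring. Among the compounds with values here, no measured compound isolates this kind of exchange, so its direction is not anchored by a neighbour. The expected step in this assay is a 1.8-fold lower number from compound 3 to compound 4 (0.26 log units; within the scatter), a modest movement toward a lower number that is not confidently beyond the scatter. Compound 4 is estimated at 30000 nM in this assay, with a range of 8000 nM to 120000 nM; a limit rather than a number remains possible given the weak potencies throughout.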

Compound 4, half-maximal inhibitory concentration: > 100000 nM
Compound 4: a limit, no number; the forecaster's own chance of this, stated with the estimate: 20%; middle value at least 3.3-fold (0.52 log units) from the limit.
By their numbers in this assay, from the lowest: compounds 1 and 2 (each within the scatter of the next); then compound 3. At a limit, above all of these: compound 4.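

In this assay, going by these compounds alone, the exchange of butyl for 4-chlorophenyl on a nitrogen on an aromatic ring gives an at least 1.8-fold higher number from compound 3 to compound 4 (0.26 log units; that floor lies within the scatter) as the first step that can be read at a single place. The step points toward a higher number, so this position is not indifferent to what sits on that nitrogen, and the larger aromatic group brings no gain here; its size cannot be stated, as only a floor is available. Compound 4 carries a limit and not a number, and it alone of the series does so: the limit of > 100000 nM in this assay, at which 1 of the 4 values shown sits.

As far as these compounds go, whether an unsubstituted phenyl on the same nitrogen would return a measurable number, and so separate the ring from the chlorine, stays open. So does the effect of a shorter chain such as methyl, or of a longer chain such as hexyl, in place of butyl.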